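Adding a methyl to a saturated ring carbon

The compounds below may be only part of what the source reports. "The series", "measured", "known", "first", "only" and "open" are said of these compounds alone.

Among the measured compounds shown here, in a functional assay (aorta) for inhibition, with Oryctolagus cuniculus as the target (a lower number here means a stronger inhibitor, a higher number a weaker inhibitor), compound 2 (`CCOC(=O)C1=C(C)N=C(C)/C(=C(/O)OCC)C1c1cccnc1`) gives 0.5 ug/mL, the lower of the two numbers so far. Compound 1 (`CCC1(c2ccccc2)C(C(=O)OC)=C(C)N=C(C)/C1=C(/O)OC`) gives 3.6 ug/mL. The gap between these two compounds lies beyond the scatter. Compound 3 (`CCOC(=O)C1=C(C)N=C(C)/C(=C(/O)OCC)C1(C)c1cccnc1`) differs from compound 2 in one place: methyl in place of hydrogen on a saturated ring carbon. For the measured compounds named here, no measured pair shows this change, but compound 1, which also lacks a hydrogen on that carbon, stands at 3.6 ug/mL, so a weaker inhibitor is expected. The expected step, beyond the scatter, is a 6.0-fold higher number from compound 2 to compound 3 (0.78 log units; beyond the scatter). For compound 3 the estimated value is 3 ug/mL, within a range of 0.7 ug/mL to 15 ug/mL.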

Compound 3, half-maximal inhibitory concentration: 9 ug/mL
Compound 3: the middle estimate sits 3.0-fold (0.48 log units) below what was measured, within the range that was stated.
By their numbers in this assay, from the lowest: compound 2; then compound 1; then compound 3.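

Among the compounds shown here, compound 2 and compound 3 form the first measured pair that isolates this change. In this assay the pair gives an 18-fold higher number from compound 2 to compound 3 (1.26 log units; beyond the scatter) for methyl in place of hydrogen on the saturated ring carbon, so one added carbon at this position is enough for a large loss of inhibition. No measurement at hand bears on why the loss occurs. On these data alone, whether a hydroxyl group or an amine on this carbon would cost as much remains open, as does whether the same step would appear on the core of compound 1.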